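Bis-arylidene series: halogen swap on the arylidene ring

The compounds below may be only part of what the source reports. "The series", "measured", "known", "first", "only" and "open" are said of these compounds alone.

Compound 1 `COc1ccccc1/C=c1/[nH]c(=O)/c(=C\c2ccccc2OC)[nH]c1=O` carries 2-methoxyphenyl on both arylidene positions, and in a functional assay on MCF7 cells (Homo sapiens) for cytotoxicity, read by CCK-8 assay, with a stated time of 72 h (on this read-out higher numbers stand for weaker inhibition and lower numbers for stronger inhibition), compound 1 is reported as "not active" (no number reported), with no number given. Within the data shown here, compound 2 `C=CCn1c(=O)/c(=C\c2cccc(F)c2)[nH]c(=O)/c1=C\c1ccccc1OC` holds the only number so far: in this assay compound 2 gives 13700 nM, while the one further entry, compound 1, is without a single number, so no ranking is possible. Compound 3 `C=CCn1c(=O)/c(=C\c2ccccc2Cl)[nH]c(=O)/c1=C\c1ccccc1OC` is not yet measured. Its difference from compound 2 is 2-chlorophenyl in place of 3-fluorophenyl on a double-bonded chain carbon bound to an aromatic carbon. Among the measured compounds shown here, no step between two measured compounds is available to calibrate a change of this kind, so the expected step of a 1.1-fold lower number from compound 2 to compound 3 (0.06 log units; within the scatter) is taken as none beyond the usual scatter, in no particular direction. For compound 3 the estimate in this assay is 12000 nM, with a range from 4000 nM to 40000 nM, the wide range reflecting that compound 2 with 13700 nM is the sole anchor.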

Compound 3, half-maximal inhibitory concentration: 4700 nM
Compound 3: middle estimate off by 2.6-fold (0.41 log units), on the high side; the measured number falls inside the stated range.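

In this assay, among these compounds, the exchange of 3-fluorophenyl for 2-chlorophenyl on a double-bonded chain carbon bound to an aromatic carbon gives a 2.9-fold lower number from compound 2 to compound 3 (0.46 log units; beyond the scatter) and is the first readable step. The place therefore responds to this exchange, although the two groups match in heavy-atom count, ring type, hydrogen-bond donors and acceptors, and net charge. Nothing available bears on the reason for the step.

Going by these compounds, the step changes both the halogen and its place on the phenyl ring, so the share of each in the lower number stays open. Also open, on these data alone, is how a phenyl group carrying an amine or a carboxylic acid would read at this place.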